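The source may hold more compounds than are shown below. What is called first, only, known or untested is meant among the compounds shown, and "the series" means these compounds.

In a functional assay on A549 cells (Homo sapiens) for antiproliferative activity, read by MTT assay, with a stated time of 48 h (on this read-out higher numbers stand for weaker inhibition and lower numbers for stronger inhibition), three esters built on one shared core have been tested so far. Compound 1 `C/C(=C\CC/C(C)=C/CC[C@@H]1[C@@]2(C)CCC(=O)C(C)(C)[C@H]2CC[C@@]1(C)O)CC/C=C(\C)C(=O)OCc1cn(-c2ccc(F)cc2)nn1` gives > 150000 nM, which is a limit and not a number. Compound 2 `COc1ccccc1-n1cc(COC(=O)/C(C)=C/CC/C(C)=C/CC/C(C)=C/CC[C@@H]2[C@@]3(C)CCC(=O)C(C)(C)[C@H]3CC[C@@]2(C)O)nn1` gives > 150000 nM, also a limit. Compound 3 `C/C(=C\CC/C(C)=C/CC[C@@H]1[C@@]2(C)CCC(=O)C(C)(C)[C@H]2CC[C@@]1(C)O)CC/C=C(\C)C(=O)OCc1cn(-c2ccccc2Br)nn1` gives > 150000 nM, again a limit. Compound 3 therefore has no number of its own and stands with the other two, as the summary shows: the limit of > 150000 nM in this assay, at which 3 of the 3 values shown sit.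

Compound 4 `C#CCOC(=O)/C(C)=C/CC/C(C)=C/CC/C(C)=C/CC[C@@H]1[C@@]2(C)CCC(=O)C(C)(C)[C@H]2CC[C@@]1(C)O` carries ethynyl in place of 1-(2-bromophenyl)-1H-1,2,3-triazol-4-yl, on a saturated chain carbon bound to an oxygen next to a carbonyl group: ethynyl in place of 1-(2-bromophenyl)-1H-1,2,3-triazol-4-yl on a saturated chain carbon bound to an oxygen next to a carbonyl group.

The measured steps only exchange the group on an aromatic nitrogen: a step that the two limits leave unreadable from compound 1 to compound 2, a step that the two limits leave unreadable from compound 1 to compound 3 and a step that the two limits leave unreadable from compound 2 to compound 3. None has a readable size, and none removes the whole group as this change does. They offer no direction, so no step beyond the scatter is expected in this assay, and the expected step is a number no higher from compound 3 to compound 4 (the limit leaves the size open). For compound 4 the estimated value is 150000 nM, with an expected range from 60000 nM to 300000 nM.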

Compound 4, half-maximal inhibitory concentration: 45100 nM
Estimate against measurement, compound 4: 3.3-fold (0.52 log units) above, and the stated range ends above it.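

On the saturated chain carbon bound to an oxygen next to a carbonyl group, ethynyl in place of 1-(2-bromophenyl)-1H-1,2,3-triazol-4-yl gives an at least 3.3-fold lower number from compound 3 to compound 4 (0.52 log units; beyond the scatter), and ethynyl in place of 1-(4-fluorophenyl)-1H-1,2,3-triazol-4-yl gives an at least 3.3-fold lower number from compound 1 to compound 4 (0.52 log units; beyond the scatter). For the compounds shown here, this shows that a change at this place can bring a readable number in this assay, something the earlier compounds could not show, as the steps among compounds 1, 2 and 3 cannot be read. Only one compound of the four has left the limit behind: the limit of > 150000 nM in this assay, at which 3 of the 4 values shown sit.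

Going by these compounds, the full size of these steps stays open, and so does whether ethynyl itself matters or only the loss of the larger group. On these data alone, how a free carboxylic acid or a plain methyl ester at this place would read in this assay also remains open.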